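A few compounds are considered here, and "the series" means these few. Any claim that something is new, unique, unknown or untested is made for them only; others in the source may bear on it.

Among the compounds with values here, the three compounds measured so far share one core and differ only in the group carried on one aromatic carbon. Compound 1 `C[S+]([O-])c1ccc(CNC(=O)c2ccc(C(C)(C)C)cc2)cc1` gives 1300 nM in an assay on HeLa cells with Bile acid receptor (Homo sapiens) as the target, read by a luciferase reporter, with a stated time of 24 h; on this read-out higher numbers stand for an effect only at larger amounts of compound and lower numbers for an effect already at smaller amounts. Compound 2 `CN(C)C(=O)c1ccc(CNC(=O)c2ccc(C(C)(C)C)cc2)cc1` gives 170 nM in this assay, and compound 3 `CC(C)(C)c1ccc(C(=O)NCc2ccc(OC(F)(F)F)cc2)cc1` gives 160 nM. Compound 3 thus holds the lowest of the three numbers; its nearest neighbour is compound 2, within the scatter, and its furthest step is an 8.1-fold lower number from compound 1 to compound 3 (0.91 log units; beyond the scatter). The steps of a 7.6-fold lower number from compound 1 to compound 2 (0.88 log units; beyond the scatter) and an 8.1-fold lower number from compound 1 to compound 3 (0.91 log units; beyond the scatter) show that the group on that aromatic carbon can move the number by a modest amount, while the step of a 1.1-fold lower number from compound 2 to compound 3 (0.03 log units; within the scatter) shows two unlike groups there giving numbers within the scatter of each other. Compound 4 `COc1ccc(CNC(=O)c2ccc(C(C)(C)C)cc2)cc1` differs from compound 3 by methyl in place of trifluoromethyl on an oxygen on an aromatic ring, which read one bond further out is trifluoromethoxy to methoxy. Within the data shown here, no measured step involves methoxy, so the expectation rests only on the spread seen across compounds 1, 2 and 3. For compound 4 the account expects a 2.5-fold higher number from compound 3 to compound 4 (0.40 log units; beyond the scatter), a step that may stay within the scatter or grow to the modest size already seen among the measured compounds. Compound 4 is therefore estimated at 400 nM, with a range from 120 nM to 1300 nM.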

Compound 4, half-maximal effective concentration: 150 nM
The estimate for compound 4 lay 2.7-fold (0.43 log units) above the measured number; the measured number falls inside the stated range.
By their numbers in this assay, from the lowest: compounds 4, 3 and 2 (each within the scatter of the next); then compound 1.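

Putting methyl in place of trifluoromethyl on the oxygen on the aromatic ring leaves the number in this assay within the scatter (a 1.1-fold lower number from compound 3 to compound 4 (0.03 log units; within the scatter)), so the three fluorine atoms of trifluoromethoxy make no difference that this read-out can resolve among these compounds. Methoxy also reads alike with dimethylcarbamoyl (a 1.1-fold lower number from compound 2 to compound 4 (0.05 log units; within the scatter)), so what was one coincidence between two unlike groups now holds for three: trifluoromethoxy, dimethylcarbamoyl and methoxy, of very different sizes, all give numbers within the scatter of each other. Compound 1 is thus the only one of the four that stands apart, and the smallest group of the set separates from it by a step of the same modest size as the larger groups do (an 8.7-fold lower number from compound 1 to compound 4 (0.94 log units; beyond the scatter)), so size alone does not order the numbers here.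

Nothing shown here accounts for why these three groups read alike or why the sulfur-bearing group of compound 1 stands apart. On these data alone, what an amine, a carboxylic acid or a longer chain such as ethoxy would give on that aromatic carbon stays open, as does whether any group there can take the number clearly lower than compounds 2, 3 and 4.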